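The compounds below may be only part of what the source reports. "The series", "measured", "known", "first", "only" and "open" are said of these compounds alone.

Compound 1 `O=C(Nc1ccc(O)c2c(=O)cc(-c3ccccc3Cl)oc12)c1ccccc1`: 7100 nM
Compound 2 `C[C@@H](NC(=O)OC(C)(C)C)C(=O)Nc1ccc(O)c2c(=O)cc(-c3ccccc3Cl)oc12`: 5500 nM

In a functional assay on MCF7 cells (Homo sapiens) for antiproliferative activity (a lower number here means a stronger inhibitor, a higher number a weaker inhibitor), compound 2 gives 5500 nM and compound 1 gives 7100 nM, so the two stand level within the scatter. Compound 3 `C[C@H](NC(=O)OC(C)(C)C)C(=O)Nc1ccc(O)c2c(=O)cc(-c3ccccc3Cl)oc12` is the next to be measured, and its change from compound 2 is small: the two compounds have the same atoms and bonds and differ only in configuration as drawn: 1 of 1 stereo elements differ; a stereocentre at a saturated chain carbon is drawn R in compound 2 and S in compound 3. Among the compounds with values here, only one measured step bears on this, a 1.3-fold lower number from compound 1 to compound 2 (0.11 log units; within the scatter). That step replaces a whole group and does not test configuration, so it gives only weak guidance. The expected change is a 1.1-fold higher number from compound 2 to compound 3 (0.04 log units; within the scatter), which is none beyond the scatter. The estimated value for compound 3 is 6000 nM, with an expected range of 2500 nM to 14000 nM.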

Compound 3, half-maximal inhibitory concentration: 5500 nM
Compound 3: middle estimate off by 1.1-fold (0.04 log units), on the high side; the range from low to high includes it.
By their numbers in this assay, from the lowest: compounds 2, 3 and 1 (each within the scatter of the next).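

Reversing the stereocentre at the saturated chain carbon from R to S shows no change at the digits printed from compound 2 to compound 3 (within the scatter) in this assay, so at this position the drawn configuration makes no visible difference, which the earlier pair could not test. The comparison is clean, as one feature alone separates the pair: the fact that compounds 2 and 3 differ only in the configuration as drawn. Against the phenyl group, the S form also stands level, with a 1.3-fold lower number from compound 1 to compound 3 (0.11 log units; within the scatter).

Still open, as far as these compounds go, is whether configuration would matter with a free amine in place of the tert-butoxycarbonyl-protected amino group, or with a longer chain on that carbon.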